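The source may report more compounds than this note shows. Statements on the series, on what has been measured and on what is new or still open speak of the compounds shown alone.

Compound 2 `O=C(CCCCCCc1nc2ccc(-c3ccccc3)cc2[nH]1)NO` has the lowest number of the three compounds measured in a functional assay on SK-OV-3 cells (Homo sapiens) for cytotoxicity (a lower number here means a stronger inhibitor, a higher number a weaker inhibitor), giving 100 nM. Compound 1 `O=C(CCCCCCc1nc2ccc(F)cc2[nH]1)NO` gives 1900 nM, and the change to compound 2 brought a 19-fold lower number from compound 1 to compound 2 (1.28 log units; beyond the scatter). Compound 3 `CN(C)c1ccc(-c2ccc3nc(CCCCCCC(=O)NO)[nH]c3c2)cc1` gives 6600 nM, reached through a 66-fold higher number from compound 2 to compound 3 (1.82 log units; beyond the scatter). Compound 4 `COc1ccc2nc(CCCCCCC(=O)NO)[nH]c2c1` has not yet been measured in this assay; its change from compound 2 is methoxy in place of phenyl on an aromatic carbon. Going by the values given here, the one measured step that bears on this runs the other way: putting the phenyl in gave a 19-fold lower number from compound 1 to compound 2 (1.28 log units; beyond the scatter), so taking it out is expected to give back most of that gain, while no measured step shows how methoxy compares with fluoro. Compound 4 is therefore expected to show a 15-fold higher number from compound 2 to compound 4 (1.18 log units; beyond the scatter). The estimated value for compound 4 is 1500 nM, with a range from 500 nM to 5000 nM.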

Compound 4, half-maximal inhibitory concentration: 11000 nM
Beside the measured number, compound 4's estimate is 7.3-fold (0.87 log units) below it; measured number outside the range, above it.
By their numbers in this assay, from the lowest: compound 2; then compound 1; then compounds 3 and 4 (each within the scatter of the next).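

At this aromatic carbon, a plain phenyl now stands well apart from methoxy, with a 110-fold higher number from compound 2 to compound 4 (2.04 log units; beyond the scatter). Methoxy can also now be set against fluoro, with a 5.8-fold higher number from compound 1 to compound 4 (0.76 log units; beyond the scatter), so neither small group comes close to phenyl. Having a ring here is not enough on its own: a 1.7-fold higher number from compound 3 to compound 4 (0.22 log units; within the scatter), so compound 3, with its 4-(dimethylamino)phenyl, cannot be told apart from compound 4.

Nothing available explains these differences. Still open, going by these compounds, is whether a phenyl carrying a single chlorine or methyl, or a pyridine ring in its place, would stay close to compound 2.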